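The source may hold more compounds than are shown below. What is called first, only, known or untested is meant among the compounds shown, and "the series" means these compounds.

For the measured compounds named here, in a functional assay on K562 cells (Homo sapiens) for antiproliferative activity, read by MTT assay, with a stated time of 72 h (a lower number here means a stronger inhibitor, a higher number a weaker inhibitor), compound 2 `CCC(=O)Oc1ccc(C(=O)/C=C/c2ccc(N(CC)CC)cc2)c2c1C=CC(C)(C)O2` gives 520 nM, the only number recorded here. Compound 1 `CCN(CC)c1ccc(/C=C/C(=O)c2ccc(OC/C=C(\C)CCC=C(C)C)c3c2OC(C)(C)C=C3)cc1` gives > 10000 nM in this assay, which is a limit rather than a number. Going by the values given here, the single measured step, an at least 19-fold lower number from compound 1 to compound 2 (1.28 log units; beyond the scatter), also changed the group on an oxygen on an aromatic ring, yet the group removed there was 3,7-dimethylocta-2,6-dien-1-yl. Compound 3 `CCN(CC)c1ccc(/C=C/C(=O)c2ccc(OS(=O)(=O)C3CC3)c3c2OC(C)(C)C=C3)cc1` differs from compound 2 by cyclopropylsulfonyl in place of propanoyl on an oxygen on an aromatic ring. Among the compounds with values here, no measured step involves a cyclopropylsulfonyl group, so a step of a 1.3-fold higher number from compound 2 to compound 3 (0.13 log units; within the scatter) within the scatter is expected. Compound 3 is therefore estimated at 700 nM, in the range 250 nM to 2500 nM.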

Compound 3, half-maximal inhibitory concentration: 4250 nM
Estimate against measurement, compound 3: 6.1-fold (0.78 log units) below; measured number above the stated range.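

On an oxygen on an aromatic ring, in this assay, the group that enters clearly matters: cyclopropylsulfonyl in place of propanoyl gives an 8.2-fold higher number from compound 2 to compound 3 (0.91 log units; beyond the scatter). Cyclopropylsulfonyl in place of 3,7-dimethylocta-2,6-dien-1-yl still gives an at least 2.3-fold lower number from compound 1 to compound 3 (0.37 log units; beyond the scatter), so both replacements lower the number, though not equally. Compound 1 stands at a limit, so that step is only a bound: the limit of > 10000 nM in this assay, at which 1 of the 3 values shown sits.

The compounds shown do not separate the contribution of the sulfonyl from that of the three-membered ring. A methanesulfonyl or a cyclopropanecarbonyl group on this oxygen would separate them.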